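Flipping one ring stereocentre in a peroxide acid

This account rests on a few compounds, and the source may have more. Where it says the series, first, only, none or still open, it means among the compounds named here.

Among the compounds with values here, compound 1, with structure `C=C1CCC[C@H]2[C@](C)(CC[C@]3(C)CC[C@@H]([C@@H](C)C(=O)O)OO3)[C@@H](C)CC[C@]12C`, is the only compound here with a definite number in a functional assay on MDA-MB-231 cells (Homo sapiens) for inhibition (on this read-out higher numbers stand for weaker inhibition of growth and lower numbers for stronger inhibition of growth), where compound 1 gives 1810 nM. Compound 2, with structure `C=C1CCCC(C)(C)C1(O)CC/C(C)=C/CC[C@]1(C)CC[C@@H]([C@@H](C)C(=O)OC)OO1`, does not yield a number in this assay but only a limit of > 17500 nM. Within the data shown here, the one other value shown is therefore (the limit of > 17500 nM in this assay, at which 1 of the 2 values shown sits), so compound 1 stands alone as the single measured point to compare against.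

Compound 3, with structure `C=C1CCC[C@H]2[C@](C)(CC[C@]3(C)CC[C@H]([C@@H](C)C(=O)O)OO3)[C@@H](C)CC[C@]12C`, keeps every atom and bond of compound 1; the only difference is the two compounds have the same atoms and bonds and differ only in configuration as drawn: 1 of 7 stereo elements differ; a stereocentre at a saturated ring carbon is drawn S in compound 1 and R in compound 3. Among the measured compounds shown here, no measured pair in this set differs by such a change, so there is no prior step to lean on. A single inversion at a saturated ring carbon is expected to leave growth inhibition close to that of compound 1, with at most a modest weakening, so the step from compound 1 to compound 3 is estimated at a 1.4-fold higher number from compound 1 to compound 3 (0.14 log units; within the scatter). For compound 3 in this assay the expected value is 2500 nM, within a range from 800 nM to 8000 nM.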

Compound 3, concentration for 50% growth inhibition: 3710 nM
For compound 3 the middle estimate is 1.5-fold (0.17 log units) below the measured one; the range from low to high includes it.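

In this assay, inverting this one saturated ring carbon from S to R gives a 2.0-fold higher number from compound 1 to compound 3 (0.31 log units; beyond the scatter), a modest weakening of growth inhibition that lies just beyond the usual scatter. Within the data shown here, this is the first measured step in the set, and it shows that the configuration drawn at this carbon registers on this read-out, although compound 3 still gives a definite value of 3710 nM. With atoms and bonds unchanged, configuration is the only difference available to explain the shift within this pair: the fact that compounds 1 and 3 differ only in the configuration as drawn

On these data alone, whether the same preference holds with an amide in place of the carboxylic acid remains open. So does the effect of inverting any of the other stereo elements, as this single pair speaks only for this one carbon on this one core.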